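The compounds below may be only part of what the source reports. "The series", "measured", "known", "first", "only" and "open" are said of these compounds alone.

Working notes on the series. The shared core carries an amine whose carbon substituent is varied. In an assay on HEK293 cells for displacement of a labelled ligand from Melanocortin receptor 4 (Homo sapiens) (a higher number here means a weaker inhibitor, a lower number a stronger inhibitor), compound 1 `CCN[C@H](c1cc(C(F)(F)F)ccc1N1CCN(C(=O)CCc2ccc(Cl)cc2Cl)CC1)C(C)CC` gives 92 nM, compound 2 `CCC(C)CN[C@H](c1cc(C(F)(F)F)ccc1N1CCN(C(=O)CCc2ccc(Cl)cc2Cl)CC1)C(C)CC` gives 2800 nM, and compound 3 `CCC(C)[C@H](NCC1CCCO1)c1cc(C(F)(F)F)ccc1N1CCN(C(=O)CCc2ccc(Cl)cc2Cl)CC1` gives 780 nM, the second highest of the three, with steps an 8.5-fold higher number from compound 1 to compound 3 (0.93 log units; beyond the scatter) and a 3.6-fold lower number from compound 2 to compound 3 (0.56 log units; beyond the scatter). Compound 4 `CCC(C)[C@H](NCCN)c1cc(C(F)(F)F)ccc1N1CCN(C(=O)CCc2ccc(Cl)cc2Cl)CC1` differs from compound 3 by aminomethyl in place of oxolan-2-yl on a saturated chain carbon bound to an amine nitrogen. Among the measured compounds shown here, the steps that bear on this change are a 30-fold higher number from compound 1 to compound 2 (1.48 log units; beyond the scatter) and an 8.5-fold higher number from compound 1 to compound 3 (0.93 log units; beyond the scatter): the smaller group at this position gives the lower number. Aminomethyl is smaller than oxolan-2-yl, so a modest fall toward compound 1 is expected in this assay, a 3.1-fold lower number from compound 3 to compound 4 (0.49 log units; beyond the scatter). Compound 4 is therefore estimated at 250 nM, within 80 nM to 800 nM.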

Compound 4, inhibition constant: 56 nM
Estimate against measurement, compound 4: 4.5-fold (0.65 log units) above; the whole stated range lies above it.
By their numbers in this assay, from the lowest: compounds 4 and 1 (each within the scatter of the next); then compound 3; then compound 2.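

In this assay, the two short groups, methyl and aminomethyl, sit apart from the larger oxolan-2-yl and sec-butyl, and aminomethyl in place of those two gives large steps (a 14-fold lower number from compound 3 to compound 4 (1.14 log units; beyond the scatter); a 50-fold lower number from compound 2 to compound 4 (1.70 log units; beyond the scatter)). Amino in place of hydrogen on the chain carbon, two bonds along the chain from the amine nitrogen, leaves the value unresolved from that of the ethyl side chain (a 1.6-fold lower number from compound 1 to compound 4 (0.22 log units; within the scatter)). No evidence on the cause of these steps is at hand. Open, on these data alone, is whether the terminal amine matters at all or only the chain length, which a hydroxyl in its place or a longer aminopropyl chain would separate.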